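Ring enlargement at the amine of the shared core

The source may report more compounds than this note shows. Statements on the series, on what has been measured and on what is new or still open speak of the compounds shown alone.

Measured compounds and their values:
- compound 1, `COc1cc2ncnc(N3CCc4ccccc43)c2cc1NC(=O)C=C(C)C`: 7840 nM
- compound 2, `CCC/C=C/C(=O)Nc1cc2c(N3CCc4ccccc43)ncnc2cc1OC`: 4240 nM
- compound 3, `CCC/C=C/C(=O)Nc1cc2c(N3CCc4ccccc43)ncnc2cc1O[C@@H]1CCOC1`: 9230 nM

In a functional assay on PC-3 cells (Homo sapiens) for antiproliferative activity, read by MTT assay, with a stated time of 72 h (on this read-out higher numbers stand for weaker inhibition and lower numbers for stronger inhibition), compound 2 gives the lowest number of the three; against compound 1 the gap is within the scatter, against compound 3 it is beyond it. The steps recorded so far are a 1.8-fold lower number from compound 1 to compound 2 (0.27 log units; within the scatter) and a 2.2-fold higher number from compound 2 to compound 3 (0.34 log units; beyond the scatter), one at the carbonyl carbon, one at the ring oxygen.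

Compound 4, `CCC/C=C/C(=O)Nc1cc2c(N3CCCc4ccccc43)ncnc2cc1OC`, differs from compound 2 by 1,2,3,4-tetrahydroquinolin-1-yl in place of 2,3-dihydro-1H-indol-1-yl on an aromatic carbon. Neither measured step touches this position, so no step beyond the scatter is expected, a 1.1-fold higher number from compound 2 to compound 4 (0.03 log units; within the scatter). In this assay compound 4 is expected to give 4500 nM, with a range from 1500 nM to 13000 nM.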

Compound 4, half-maximal inhibitory concentration: 2240 nM
Compound 4: the middle estimate sits 2.0-fold (0.30 log units) above what was measured; measured number inside the range.
By their numbers in this assay, from the lowest: compounds 4, 2, 1 and 3 (each within the scatter of the next, the first and the last beyond it).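

In this assay, within the data shown here, this is the first reading at the position on an aromatic carbon next to the ring nitrogen: a 1.9-fold lower number from compound 2 to compound 4 (0.28 log units; within the scatter). A six-membered non-aromatic ring can therefore replace the five-membered one here, with one more heavy atom, without a step beyond the scatter. No available evidence bears on this reading.

On these data alone, it remains open whether an open-chain N-methylanilino group or a morpholine would hold the number at this position. Also open, as far as these compounds go, is whether the same exchange reads alike with the oxolan-3-yl group of compound 3 on the oxygen.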